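Allyloxy to methoxy in compound 2

The compounds below may be only part of what the source reports. "The series", "measured", "known", "first", "only" and "open" are said of these compounds alone.

Measured so far in a functional assay on SK-BR-3 cells (Homo sapiens) for cytotoxicity, read by CellTiter-Glo, with a stated time of 72 h (a higher number here means a weaker inhibitor, a lower number a stronger inhibitor), the values stand as follows:
Compound 1 `CO[C@H]1C[C@H](C)CC2=C(N3CCC3)C(=O)C=C(NC(=O)/C(C)=C/C=C\[C@H](OC)[C@@H](OC(N)=O)/C(C)=C/[C@H](C)/C1=N\O)C2=O` gives 310 nM
Compound 2 `C=CCO/N=C1/[C@@H](OC)C[C@H](C)CC2=C(NCCN(C)C)C(=O)C=C(NC(=O)/C(C)=C/C=C\[C@H](OC)[C@@H](OC(N)=O)/C(C)=C/[C@@H]1C)C2=O` gives 400 nM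
Compound 3 `CO[C@H]1C[C@H](C)CC2=C(NCCN(C)C)C(=O)C=C(NC(=O)/C(C)=C/C=C\[C@H](OC)[C@@H](OC(N)=O)/C(C)=C/[C@H](C)C1=O)C2=O` gives 100 nM

Compound 2 (400 nM) lies within the scatter of compound 1 (310 nM). Compound 3 (100 nM) carries a lower number than compound 2, and that gap lies beyond the scatter. No two of these three compounds differ in one place only, so their values do not isolate the effect of any single change.

The next compound to be tested is compound 4 `CO/N=C1/[C@@H](OC)C[C@H](C)CC2=C(NCCN(C)C)C(=O)C=C(NC(=O)/C(C)=C/C=C\[C@H](OC)[C@@H](OC(N)=O)/C(C)=C/[C@@H]1C)C2=O`, which departs from compound 2 in one place (hydrogen in place of vinyl on a saturated chain carbon bound to an oxygen on an unsaturated carbon). Hydrogen stands in place of vinyl on a saturated chain carbon bound to an oxygen on an unsaturated carbon, which, cut one bond further out, reads allyloxy to methoxy. Within the data shown here, none of the measured compounds shows what this change does, and the expectation therefore starts from compound 2 at 400 nM and allows a wide margin on either side. In this assay the estimated step of a 1.3-fold lower number from compound 2 to compound 4 (0.10 log units; within the scatter) is expected to stay within the scatter, with no firm direction. The expected value for compound 4 is 320 nM, estimated to fall in the range from 130 nM to 800 nM when measured.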

Compound 4, half-maximal inhibitory concentration: 550 nM
Compound 4: the middle estimate sits 1.7-fold (0.24 log units) below what was measured; low and high end bracket the measured number.
By their numbers in this assay, from the lowest: compound 3; then compounds 1, 2 and 4 (each within the scatter of the next).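

In this assay, the change from allyloxy to methoxy gives a 1.4-fold higher number from compound 2 to compound 4 (0.14 log units; within the scatter), the first step among these compounds that isolates one change at one place. At this place, a saturated chain carbon bound to an oxygen on an unsaturated carbon, vinyl gives way to hydrogen with a step that stays within the scatter, so this read-out does not tell the allyloxy and methoxy forms apart in this pair. No measurement given here offers an explanation for this result.

The compounds shown leave open whether any other group at this place, such as a longer chain, a benzyl group, or a chain ending in an amine or a carboxylic acid, would produce a step beyond the scatter. Among these compounds, they also leave open whether allyloxy to methoxy would read the same way on the core of compound 1, since this single pair shares the side chain of compound 2 and gives only one reading of the change.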